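Removing the nitro group from an antiproliferative amide

The compounds below may be only part of what the source reports. "The series", "measured", "known", "first", "only" and "open" are said of these compounds alone.

Three compounds share a core that carries an amide and a dithiocarbamate, and differ in the amine attached to that dithiocarbamate. Compound 1 `Nc1ccccc1NC(=O)c1ccc(CSC(=S)N2CCN(c3ccc(Cl)cc3)CC2)cc1` gives 29% in a functional assay on A-375 cells (Homo sapiens) for antiproliferative activity, read by CCK-8 assay, with a stated time of 72 h, tested at 8 uM; a lower number here means a weaker effect, a higher number a stronger effect of the compound at the concentration tested. For the measured compounds named here, compound 3 `Nc1ccccc1NC(=O)c1ccc(CSC(=S)N2CCN(c3cnccn3)CC2)cc1` gives 85.8%, so the step of a number 56.8 percentage points higher from compound 1 to compound 3 (beyond the scatter) is the only comparison of two measured compounds here. Compound 2 `Nc1ccccc1NC(=O)c1ccc(CSC(=S)N2CCc3ccc([N+](=O)[O-])cc32)cc1` gives 42% and stands second of the three, above compound 1 and well below compound 3.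

Compound 4 `Nc1ccccc1NC(=O)c1ccc(CSC(=S)N2CCc3ccccc32)cc1` differs from compound 2 in one place: hydrogen in place of nitro on an aromatic carbon. Going by the values given here, no measured pair shows this kind of change; the single measured step concerns a different ring and a different kind of swap, so it bears only loosely on what to expect. With nothing to point in either direction, a step from compound 2 to compound 4 no larger than the scatter is expected, as a number 6 percentage points lower from compound 2 to compound 4 (within the scatter). Compound 4 is therefore estimated at 36% in this assay, within a range from 15% to 58%.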

Compound 4, a percentage reported as inhibition, at one concentration (the size of the read-out at that concentration, not a potency): 85.4%
Compound 4: the middle estimate sits 49.4 percentage points below what was measured; the whole stated range lies below it.
By their numbers in this assay, from the lowest: compound 1; then compound 2; then compounds 4 and 3 (each within the scatter of the next).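

Replacing the nitro group with hydrogen on an aromatic carbon of the six-membered ring of carbon only gives a number 43.4 percentage points higher from compound 2 to compound 4 (beyond the scatter) in this assay. For the compounds shown here, the only earlier step was a swap on an amine nitrogen in a ring, so this is the first sign that a single change at this other position can also move the read-out by a large amount. No measurement shown here explains why the read-out moves this much.

Going by these compounds, it remains open whether this step is specific to the nitro group or whether other groups on this carbon, such as an amine, a methoxy group or a fluorine atom, would give a similar number. On these data alone, each number also comes from one concentration, so the potency of compound 2 and compound 4 remains unknown.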